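Methoxymethyl Added to the Unsaturated Core of Compound 3

The source may report more compounds than this note shows. Statements on the series, on what has been measured and on what is new or still open speak of the compounds shown alone.

Of the compounds shown here, three have been measured in an assay on HEK293 cells for displacement of a labelled ligand from Neuronal acetylcholine receptor; alpha4/beta2 (Rattus norvegicus), with a stated time of 4 h; on this read-out lower numbers stand for stronger inhibition and higher numbers for weaker inhibition. Compound 1 `CO[C@H]1CC[C@H]2CCN(C)[C@H]2C1` gives 300000 nM, and compound 2 `COCCO[C@H]1CC[C@H]2CCN(C)[C@H]2C1` gives 300000 nM. Compound 3 `CO[C@H]1CC=C2CCN(C)[C@H]2C1`, whose core carries a double bond, gives 3400 nM; this is the lowest of the three numbers, and the other two compounds lie beyond the scatter above it by the same wide margin.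

Compound 4 `COCCO[C@H]1CC=C2CCN(C)[C@H]2C1` has not yet been measured. It differs from compound 3 in one place: methoxymethyl in place of hydrogen on a saturated chain carbon bound to an oxygen on a saturated carbon. Going by the values given here, one measured step bears directly on this change. The same replacement was made on the saturated core of the first pair, and there it gave no change at the digits printed from compound 1 to compound 2 (within the scatter). On that basis the corresponding change on compound 3 is expected to produce no step beyond the scatter in this assay, in either direction. The expected step in this assay is therefore no change at the digits printed from compound 3 to compound 4 (within the scatter), nothing beyond the scatter. Compound 4 is estimated at 3400 nM in this assay, with a range from 1500 nM to 8000 nM. Among the compounds with values here, only one step supports this expectation, and it comes from compounds whose numbers sit far from that of compound 3, so the range is kept wide.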

Compound 4, inhibition constant: > 300000 nM
Compound 4: a limit, no number; the forecaster's own chance of this, stated with the estimate: 5%; at least 88-fold (1.94 log units) between middle value and limit.
By their numbers in this assay, from the lowest: compound 3; then compounds 1 and 2 (each within the scatter of the next).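

In this assay, the replacement of hydrogen by methoxymethyl on a saturated chain carbon bound to an oxygen on a saturated carbon proves not to be neutral on every core, since on the core carrying the double bond it gives an at least 88-fold higher number from compound 3 to compound 4 (1.94 log units; beyond the scatter). Compound 4 gives > 300000 nM, which is a limit of the assay and not a number, so the size of this step is bounded on one side only: the limit of > 300000 nM in this assay, at which 1 of the 4 values shown sits. What the first pair alone could not show is that the outcome of this one change differs with the core that carries it: the same change on two cores in this assay, no change at the digits printed (within the scatter) from compound 1 to compound 2 and an at least 88-fold higher number (1.94 log units; beyond the scatter) from compound 3 to compound 4, at least 88-fold (1.94 log units) apart, beyond the scatter of two such steps.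

The compounds shown leave open how far compound 4 really lies from compound 3, as its limit gives no number to set against the value of compound 3. They also leave open how other groups in this place would read on the core of compound 3, whether a shorter ethoxy, a 2-hydroxyethoxy chain ending in a hydroxyl, a longer alkyl chain or a chain ending in an amine.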